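The source may report more compounds than this note shows. Statements on the series, on what has been measured and on what is new or still open speak of the compounds shown alone.

Measured so far in a functional assay on KM12 cells (Homo sapiens) for antiproliferative activity, read by sulforhodamine B assay, with a stated time of 48 h; a lower number here means that less compound is tolerated, a higher number that more compound is tolerated:
- compound 1 `COc1ccc(OC)c(/C=C/c2nnc(Nc3ccc(Cl)cc3)o2)c1`: compound 1 gives > 100000 nM
- compound 2 `COc1ccc(OC)c(/C=C/C(=O)N/N=C/c2ccc(Cl)cc2)c1`: compound 2 gives > 100000 nM

Neither value is a number; both are limits of the assay: the limit of > 100000 nM in this assay, at which 2 of the 2 values shown sit. Compound 2 therefore stands at a limit of this assay, > 100000 nM, and no number for it is known. Going by the values given here, the two measured compounds share the dimethoxystyryl fragment but differ in the linker and the chloroaryl part; no step between them is counted, so nothing is said of their relation beyond the fact that both sit at the limit.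

Compound 3 `COc1ccc(OC)c(/C=C/C(=O)N/N=C/c2ccccc2)c1` has not yet been measured in this assay . It differs from compound 2 by hydrogen in place of chloro on an aromatic carbon; the same difference, cut one bond further out, reads 4-chlorophenyl to phenyl. Among the compounds with values here, no step between measured compounds is available to size this change, and since compound 2 gives only a limit, no direction can be read from the series. The expectation is that compound 3 also reaches the limit, with no step beyond the scatter: a number no higher from compound 2 to compound 3 (the limit leaves the size open). For compound 3 the estimate in this assay is 100000 nM, with a range from 40000 nM to 300000 nM.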

Compound 3, concentration lethal to 50% of the cells: 29400 nM
The estimate for compound 3 lay 3.4-fold (0.53 log units) above the measured number; measured number outside the range, below it.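

In this assay the change at this position is hydrogen in place of chloro on an aromatic carbon, para to a large group, and it gives an at least 3.4-fold lower number from compound 2 to compound 3 (0.53 log units; beyond the scatter). The earlier compounds shown here sat together at the limit and gave no direction, whereas this pair shows that going from 4-chlorophenyl to phenyl is not silent here. Of the three compounds, compound 3 alone gives a number, namely 29400 nM. The full size of the step cannot be stated because compound 2 stands at a limit and only the lower bound of the change can be read: the limit of > 100000 nM in this assay, at which 2 of the 3 values shown sit.

On these data alone, whether the shift belongs to the loss of chloro in particular or would also follow from another replacement stays open, since fluoro, methyl, methoxy or an amine on the same carbon would separate those two readings. Also open is whether the same change would act alike in the series of compound 1, whose linker differs and which has no phenyl partner among the compounds shown.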